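The compounds below may be only part of what the source reports. "The series", "measured", "known", "first", "only" and "open" are said of these compounds alone.

Compound 1 (`Nc1nc(N)c2nc(CNc3ccc(C(=O)N[C@@H](CC(F)C(=O)O)C(=O)O)cc3C(F)(F)F)cnc2n1`): in a functional assay on EL4 cells (Mus musculus) for inhibition (a higher number here means a weaker inhibitor, a lower number a stronger inhibitor), compound 1 gives > 100000 nM; > 100000 nM (2 entries).
Compound 2 (`Nc1nc(N)c2nc(CNc3ccc(C(=O)N[C@@H](CC(F)C(=O)O)C(=O)O)cc3Br)cnc2n1`): in this assay compound 2 gives only the limit > 100000 nM, a limit of the assay rather than a number.

Compound 2 therefore stands at the limit of > 100000 nM in this assay, at which 1 of the 2 values shown sits; no single number exists for it, and nothing marks it off from compound 1, whose two entries both sit at the same limit. Compound 3 (`Nc1nc(N)c2nc(CNc3ccc(C(=O)N[C@@H](CC(F)C(=O)O)C(=O)O)cc3Cl)cnc2n1`) differs from compound 2 in one place: chloro in place of bromo on an aromatic carbon. Within the data shown here, no measured step between two compounds is available to gauge such an exchange, so the expectation rests on the two limits alone. In this assay no shift beyond the usual scatter is expected in either direction. Compound 3 is expected to give 150000 nM, within a range of 50000 nM to 1000000 nM, and most likely again only a limit. The step that the limit leaves unreadable from compound 2 to compound 3 is thus estimated to be flat.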

Compound 3, half-maximal inhibitory concentration: > 100000 nM
Compound 3: a limit, no number (the forecaster's own chance of this, stated with the estimate: 85%); the middle value is on the limit's open side.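

In this assay compound 3 gives > 100000 nM, a limit of the assay and not a number. Compound 2 also sits at a limit, so no step can be read from compound 2 to compound 3: the limit of > 100000 nM in this assay, at which 2 of the 3 values shown sit. The compounds shown leave open whether chloro in place of bromo on an aromatic carbon changes anything in this assay, and what single number any of these compounds would give.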